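The source may report more compounds than this note shows. Statements on the series, on what has been measured and on what is new or still open speak of the compounds shown alone.

In a functional assay on MDA-MB-453 cells (Homo sapiens) for antiproliferative activity, read by MTT assay, with a stated time of 72 h (a higher number here means a weaker inhibitor, a lower number a stronger inhibitor), compound 1, whose structure is `O=C1NN=C(c2ccccc2)/C1=C/Nc1cc[nH]n1`, gives 74900 nM. Among the three compounds measured so far this is the second highest number. Compound 2, with structure `O=C1NN=C(c2ccccc2)/C1=C/Nc1cc(-c2ccccc2)[nH]n1`, gives 11500 nM, and compound 3, with structure `CSC[C@H](N/C=C1\C(=O)NN=C1c1ccccc1)C(=O)O`, gives 105000 nM. Two single-point changes connect them to compound 1: a 6.5-fold lower number from compound 1 to compound 2 (0.81 log units; beyond the scatter), where a phenyl replaces a hydrogen on an aromatic carbon, and a 1.4-fold higher number from compound 1 to compound 3 (0.15 log units; within the scatter), where a 1-carboxy-2-(methylsulfanyl)ethyl group replaces the 1H-pyrazol-3-yl group on an amine nitrogen, a change that stays within the scatter.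

Compound 4, with structure `O=C1/C(=C\Nc2cc[nH]n2)C(c2ccccc2)=NN1c1ccccc1`, differs from compound 1 by phenyl in place of hydrogen on an amide-type nitrogen in a ring. Within the data shown here, the only measured step that bears on this is a 6.5-fold lower number from compound 1 to compound 2 (0.81 log units; beyond the scatter), since it also introduces a phenyl, though at a different place in the shared core. Whether a phenyl on the amide-type nitrogen of the ring acts the same way is not known from these data, so the expectation is a modest move toward a lower number, possibly smaller than the measured one, and possibly none beyond the scatter. Compound 4 is therefore expected to give 35000 nM, within a range from 12000 nM to 100000 nM. That expectation corresponds to a 2.1-fold lower number from compound 1 to compound 4 (0.33 log units; beyond the scatter).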

Compound 4, half-maximal inhibitory concentration: 34700 nM
Estimate against measurement, compound 4: 1.0-fold (0.00 log units) above; low and high end bracket the measured number.
By their numbers in this assay, from the lowest: compound 2; then compound 4; then compounds 1 and 3 (each within the scatter of the next).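

In this assay, the amide-type nitrogen in the ring carries a hydrogen in compound 1, and putting a phenyl there gives a 2.2-fold lower number from compound 1 to compound 4 (0.33 log units; beyond the scatter) as a modest change. So this position accepts a group of 6 heavy atoms without any loss in this read-out, and the amide hydrogen itself is not needed for the antiproliferative activity of this series, at least at this level of potency. Together with a 6.5-fold lower number from compound 1 to compound 2 (0.81 log units; beyond the scatter), this gives two different places on compound 1 where a phenyl in place of a hydrogen goes with a lower number, and no compound shown goes against that, though the pattern rests on these two steps alone; nothing available gives a reason for the step at this nitrogen.

Still open, going by these compounds, is whether the phenyl ring matters here or whether a small methyl, a benzyl or a longer alkyl chain on the same nitrogen would lower the number as well. On these data alone, it is equally open whether the two phenyl groups would add to each other if both stood on the shared core in a single compound.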